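The source may report more compounds than this note shows. Statements on the series, on what has been measured and on what is new or still open speak of the compounds shown alone.

In a functional assay (cardiac atrium) for agonist activity, with Cavia porcellus as the target (on this read-out lower numbers stand for an effect already at smaller amounts and higher numbers for an effect only at larger amounts of compound), compound 2 `CCO/C(O)=C1\C(C)=NC(C)=C([N+](=O)[O-])C1c1cccnc1` gives 8840 nM, the higher of the two numbers recorded so far, while compound 1 `CC1=NC(C)=C([N+](=O)[O-])C(c2cccnc2)/C1=C(\O)OCC(C)C` gives 1740 nM. Compound 3 `CO/C(O)=C1\C(C)=NC(C)=C([N+](=O)[O-])C1c1cccnc1` differs from compound 2 by hydrogen in place of methyl on a saturated chain carbon bound to an oxygen on an unsaturated carbon. Among the compounds with values here, the only measured step bearing on this change is a 5.1-fold higher number from compound 1 to compound 2 (0.71 log units; beyond the scatter), where shortening the same chain raised the number. Shortening it once more is expected to raise the number again, probably by a somewhat smaller amount. Compound 3 is therefore estimated at 18000 nM, with a range of 7000 nM to 45000 nM. This corresponds to an expected 2.0-fold higher number from compound 2 to compound 3 (0.31 log units; beyond the scatter).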

Compound 3, half-maximal effective concentration: 70000 nM
Compound 3: middle estimate off by 3.9-fold (0.59 log units), on the low side; measured number above the stated range.
By their numbers in this assay, from the lowest: compound 1; then compound 2; then compound 3.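

Going from ethoxy to methoxy gives a 7.9-fold higher number from compound 2 to compound 3 (0.90 log units; beyond the scatter), so the second shortening of this chain raises the number again instead of levelling off. Taken end to end, the change amounts to a 40-fold higher number from compound 1 to compound 3 (1.60 log units; beyond the scatter), and none of the three compounds goes against the rise in the number as the chain shortens. No measurement shown here explains this rise. Within the data shown here, it remains open whether a longer chain than the one in compound 1, such as hexyl, would bring the number down further. A cyclohexyl group or a chain ending in an amine might also depart from this trend.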